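Series notes: the step from compound 3 to compound 4

The compounds below may be only part of what the source reports. "The series", "measured", "known", "first", "only" and "open" are said of these compounds alone.

Of the compounds shown here, three of the shared core have been measured in a physicochemical assay for solubility, read by LC-MS, in phosphate buffer, with a stated time of 24 h, at pH 7.4; a lower number here means a less soluble compound, a higher number a more soluble compound. Compound 1 `CN(c1ccn(C)n1)c1cnc(NCc2c(F)ccc3c2CCO3)c2cn[nH]c(=O)c12` gives 12000 nM. Compound 2 `Cn1cc(-c2cnc(NCc3c(F)ccc4c3CCO4)c3cn[nH]c(=O)c23)cn1` gives 1000 nM, and compound 3 `Cn1nccc1-c1cnc(NCc2c(F)ccc3c2CCO3)c2cn[nH]c(=O)c12` gives 2000 nM. Compound 3 stands second highest of the three numbers: its nearest neighbour is compound 2, with a 2.0-fold higher number from compound 2 to compound 3 (0.30 log units; within the scatter), and its furthest is compound 1, with a 6.0-fold lower number from compound 1 to compound 3 (0.78 log units; beyond the scatter).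

Compound 4 `Cc1nc(CO)ccc1-c1cnc(NCc2c(F)ccc3c2CCO3)c2cn[nH]c(=O)c12` is the next compound, not yet measured. It differs from compound 3 in one place: 6-(hydroxymethyl)-2-methylpyridin-3-yl in place of 1-methyl-1H-pyrazol-5-yl on an aromatic carbon.

Two measured steps alter the same position. Replacing methyl(1-methyl-1H-pyrazol-3-yl)amino by 1-methyl-1H-pyrazol-4-yl gave a 12-fold lower number from compound 1 to compound 2 (1.08 log units; beyond the scatter), and by 1-methyl-1H-pyrazol-5-yl gave a 6.0-fold lower number from compound 1 to compound 3 (0.78 log units; beyond the scatter), while the exchange of one five-membered ring for the other gave a 2.0-fold higher number from compound 2 to compound 3 (0.30 log units; within the scatter). Among the measured compounds shown here, no measured step exchanges a five-membered ring for a six-membered one, and none brings in a hydroxymethyl, so the direction for compound 4 is uncertain; the only step between two five-membered rings stayed within the scatter, and the range is widened accordingly. Compound 4 is expected to show a step of a 1.5-fold higher number from compound 3 to compound 4 (0.18 log units; within the scatter). The estimate for compound 4 is 3000 nM, in the range 800 nM to 12000 nM.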

Compound 4, solubility: 3000 nM
Beside the measured number, compound 4's estimate shows no gap at the digits printed, within the range that was stated.
By their numbers in this assay, from the lowest: compounds 2, 3 and 4 (each within the scatter of the next, the first and the last beyond it); then compound 1.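

In this assay, a six-membered aromatic ring at this position does not separate from the five-membered 1-methyl-1H-pyrazol-5-yl: the step is a 1.5-fold higher number from compound 3 to compound 4 (0.18 log units; within the scatter), even with more heavy atoms and a hydrogen-bond donor in the entering group. Against the other five-membered ring the picture differs, with a 3.0-fold higher number from compound 2 to compound 4 (0.48 log units; beyond the scatter), so 6-(hydroxymethyl)-2-methylpyridin-3-yl and 1-methyl-1H-pyrazol-4-yl are resolved even though each lies within the scatter of 1-methyl-1H-pyrazol-5-yl. Methyl(1-methyl-1H-pyrazol-3-yl)amino still gives the highest number of the series, with a 4.0-fold lower number from compound 1 to compound 4 (0.60 log units; beyond the scatter), so none of the three groups without the methylamino link reaches compound 1, and the six-membered ring narrows that gap only as far as the scatter allows it to be read.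

On these data alone, the methyl and the hydroxymethyl enter together on one ring, so the share of each cannot be read, and what an amine or a carboxylic acid in place of the hydroxymethyl would give remains open. Nothing available explains why the numbers fall as they do.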